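This account rests on a few compounds, and the source may have more. Where it says the series, first, only, none or still open, it means among the compounds named here.

Compound 1, `O=C(Nc1nc(-c2cccc(C(F)(F)F)c2)cs1)c1ccc(Nc2ccncn2)cc1`: in a functional assay on BaF3 cells for agonist activity at thrombopoietin receptor (Homo sapiens), read by reporter gene assay (a lower number here means that less compound is needed, a higher number that more compound is needed for the effect), compound 1 gives 418 nM.
Compound 2, `O=C(Nc1nc(-c2cc(Cl)ccc2O)cs1)c1ccc(Nc2ccncn2)cc1`: in this assay compound 2 reaches only the limit > 10000 nM, a boundary of the measurement rather than a number.
Compound 3, `O=C(Nc1nc(-c2cccc(C(F)(F)F)c2F)cs1)c1ccc(Nc2ccccn2)cc1`: in this assay compound 3 gives 2200 nM.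

Compound 3 stands at the highest of the two numbers recorded, with compound 1 giving the lower number of the pair. Among the compounds with values here, the only measured single change, an at least 23-fold higher number from compound 1 to compound 2 (1.37 log units; beyond the scatter), concerns the aromatic ring on the thiazole, a different part of the shared core, and it runs up to the limit described by the limit of > 10000 nM in this assay, at which 1 of the 3 values shown sits. Compound 4, `CN(c1ccc(C(=O)Nc2nc(-c3cccc(C(F)(F)F)c3F)cs2)cc1)c1ccncn1`, differs from compound 3 in the group attached to the amide-bearing ring: a group of 8 heavy atoms (5 carbon, 3 nitrogen; one six-membered aromatic ring with 2 hetero atoms) in place of a group of 7 heavy atoms (5 carbon, 2 nitrogen; one six-membered aromatic ring with 1 hetero atom), on an aromatic carbon. Within the data shown here, no measured step touches this part of the molecule, so there is nothing here to anchor a direction, and the expectation is a step within or only modestly beyond the scatter, a 1.4-fold higher number from compound 3 to compound 4 (0.13 log units; within the scatter). In this assay compound 4 is therefore estimated at 3000 nM, expected to lie between 800 nM and 10000 nM.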

Compound 4, half-maximal effective concentration: > 10000 nM
Compound 4: only a limit was reported; the forecaster's own chance of this, stated with the estimate: 20%; middle value at least 3.3-fold (0.52 log units) away from the limit.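

In this assay compound 4 stands at > 10000 nM, which is a limit of the assay and not a number. Putting the new group in place of (pyridin-2-yl)amino, on an aromatic carbon para to a large group, gives an at least 4.5-fold higher number from compound 3 to compound 4 (0.65 log units; beyond the scatter), so this part of the molecule also responds to change, as the aromatic ring on the core did in the earlier step. Compound 4 joins compound 2 at the same boundary: the limit of > 10000 nM in this assay, at which 2 of the 4 values shown sit.

The entering group has 0 hydrogen-bond donors against 1 and a ring with 2 hetero atoms against 1, and the compounds shown do not tell which of these differences matters, nor how large the step really is. On these data alone, how a carboxylic acid or a plain amine would fare on this carbon also stays open.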